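The compounds below may be only part of what the source reports. "The series", "measured", "known", "first", "only" and "open" are said of these compounds alone.

Among the compounds with values here, in a functional assay on the whole organism for positive allosteric modulation, with Mus musculus as the target (on this read-out higher numbers stand for an effect only at larger amounts of compound and lower numbers for an effect already at smaller amounts), compound 1 `CCC(=O)N(c1cccc(OC)c1)C1CCCC1N(C)C` gives 0.8 mg/kg, the lowest of the three numbers measured so far. Compound 2 `CCC(=O)N(c1ccc(OC)c(OC)c1)C1CCCC1N(C)C` gives 9 mg/kg, and compound 3 `CCC(=O)N(c1ccc(Cl)c(C)c1)C1CCCC1N(C)C` gives 2 mg/kg. Compound 4 `CCC(=O)N(c1cccc(C(F)(F)F)c1)C1CCCC1N(C)C` keeps the core of compound 1 but has trifluoromethyl in place of methoxy on an aromatic carbon.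

Within the data shown here, no measured step makes this exact exchange. The closest is the addition of a methoxy in place of hydrogen on an aromatic carbon, which gives an 11-fold higher number from compound 1 to compound 2 (1.05 log units; beyond the scatter). This shows that a single change on the ring can shift the number a long way, but it adds a group rather than replacing one, so it is only a loose guide. Compound 3, which carries no methoxy, has a number of 2 mg/kg, a little higher than that of compound 1. On that evidence, the expected change is a modest one toward a higher number: a 2.3-fold higher number from compound 1 to compound 4 (0.35 log units; beyond the scatter). Compound 4 is estimated at 1.8 mg/kg, with an expected range from 0.5 mg/kg to 6 mg/kg.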

Compound 4, dose for half-maximal effect: 0.3 mg/kg
Compound 4: middle estimate off by 6.0-fold (0.78 log units), on the high side; measured number outside the range, below it.
By their numbers in this assay, from the lowest: compound 4; then compound 1; then compound 3; then compound 2.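

Replacing the methoxy with trifluoromethyl in this assay gives a 2.7-fold lower number from compound 1 to compound 4 (0.43 log units; beyond the scatter), so this position on the aromatic ring does not depend on methoxy for an effect at small amounts of compound. Within the data shown here, the earlier step showed only that adding a group to the ring of compound 1 can raise the number; this one shows that an exchange at a single place can lower it, even though the entering group has more heavy atoms and no hydrogen-bond acceptor. Nothing available here explains why the number falls with this exchange.

Going by these compounds, it remains open how other groups at this position, such as an amine, a nitrile or a carboxylic acid, would compare with trifluoromethyl. The compounds shown also leave open whether trifluoromethyl would give a similar step on another carbon of the ring.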